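Resolving one stereocentre of a succinimide-bearing acid

The source may hold more compounds than are shown below. What is called first, only, known or untested is meant among the compounds shown, and "the series" means these compounds.

Of the compounds shown here, three share a common acid scaffold and have been tested in an assay on CHO cells for displacement of a labelled ligand from C-X-C chemokine receptor type 3 (Homo sapiens), with a stated time of 60 min; a higher number here means a weaker inhibitor, a lower number a stronger inhibitor. Compound 1 `C[C@@H](c1ccc(Cl)cc1)N(Cc1ccc(OCCN2C(=O)CCC2=O)c(C(=O)O)c1)CC1CCCC1` gives 6600 nM. Compound 2 `CCN(Cc1ccc(OCCN2C(=O)CCC2=O)c(C)c1)C(CC(=O)O)c1ccc(Cl)cc1` gives 424 nM. Compound 3 `Cc1cc(CN(CC2CC2)C(CC(=O)O)c2ccc(Cl)cc2)ccc1OCCN1C(=O)CCC1=O` gives 65 nM, the lowest of the three numbers; the step of a 6.5-fold lower number from compound 2 to compound 3 (0.81 log units; beyond the scatter) separates it from its nearest neighbour compound 2, while compound 1 lies further away and differs at several places, so nothing is counted between compounds 1 and 3.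

Compound 4 `Cc1cc(CN(CC2CC2)[C@@H](CC(=O)O)c2ccc(Cl)cc2)ccc1OCCN1C(=O)CCC1=O` is the next member. Its difference from compound 3 is the two compounds have the same atoms and bonds; at least one stereo element is drawn with a configuration in one of them and without one in the other: 1 of 1 stereo elements differ; a stereocentre at a saturated chain carbon is drawn without a configuration in compound 3 and S in compound 4; no atom leaves and none enters. Compound 3 is thus a mixture of both configurations at that stereocentre, and compound 4 is one of its two components. Among the compounds with values here, no measured step isolates a stereocentre on this scaffold, so the direction of the change cannot be read from this set. If the S form carries the activity of compound 3, the number would be expected to fall by about a factor within the usual range for a resolved mixture; if not, it would rise markedly. Weighting the first case, compound 4 is expected to give 45 nM in this assay, within 15 nM to 300 nM, a step of a 1.4-fold lower number from compound 3 to compound 4 (0.16 log units; within the scatter) that is estimated, not measured.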

Compound 4, half-maximal inhibitory concentration: 42 nM
Beside the measured number, compound 4's estimate is 1.1-fold (0.03 log units) above it; low and high end bracket the measured number.
By their numbers in this assay, from the lowest: compounds 4 and 3 (each within the scatter of the next); then compound 2; then compound 1.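

In this assay, within the data shown here, the set now holds a 1.5-fold lower number from compound 3 to compound 4 (0.19 log units; within the scatter), the only step here that touches a stereocentre rather than a substituent. The S form at the saturated chain carbon thus carries activity that cannot be told apart from that of compound 3, so fixing this centre as S leaves the number where the undefined drawing had it, whereas the earlier step on this scaffold spoke only to cyclopropyl in place of methyl. The pair can be read as a mixture and one of its components, with the stereocentre as the only variable, because of how the two are drawn: the fact that one of compounds 3 and 4 is drawn with a defined configuration and the other without, at the place where they differ.

The compounds shown leave open how the R form at this carbon behaves on its own, and since the step lies within the scatter, they cannot say how much of the activity of compound 3 the R form contributes. They also leave open whether the S preference, if there is one, would hold with another group on the amine nitrogen, such as cyclobutyl in place of cyclopropyl.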